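The source may hold more compounds than are shown below. What is called first, only, known or untested is meant among the compounds shown, and "the series" means these compounds.

In a functional assay on A549 cells (Homo sapiens) for antiproliferative activity, read by MTT assay, with a stated time of 72 h (on this read-out higher numbers stand for weaker inhibition and lower numbers for stronger inhibition), compound 1 `COc1cc2ncnc(Nc3ccc(F)c(Br)c3)c2cc1OCCCN1CCNCCNCCNCC1` gives 11800 nM and compound 2 `COc1cc2ncnc(Nc3ccc(Cl)c(C(F)(F)F)c3)c2cc1OCCCN1CCNCCNCCNCC1` gives 5350 nM, so compound 2 holds the lower of the two numbers. Compound 3 `COc1cc2ncnc(Nc3cccc(F)c3)c2cc1OCCCN1CCNCCNCCNCC1` is still unmeasured. It differs from compound 2 by 3-fluorophenyl in place of 4-chloro-3-(trifluoromethyl)phenyl on a nitrogen on an aromatic ring, with 3-fluorophenyl in place of 4-chloro-3-(trifluoromethyl)phenyl on a nitrogen on an aromatic ring. For the measured compounds named here, only one measured step bears on this place: a 2.2-fold lower number from compound 1 to compound 2 (0.34 log units; beyond the scatter), a modest step just beyond the scatter. With a single step as evidence, the expectation is weak. Going by the values given here, compound 3 gives up the group found in compound 2, and the only other group measured at this place, in compound 1, goes with the higher number 11800 nM. A modest rise is therefore expected in this assay. The estimated change is a 2.1-fold higher number from compound 2 to compound 3 (0.31 log units; beyond the scatter). Compound 3 is expected at 11000 nM, with an estimated range of 4500 nM to 28000 nM.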

Compound 3, half-maximal inhibitory concentration: > 50000 nM
Compound 3: only a limit was reported; the forecaster's own chance of this, stated with the estimate: 7%; at least 4.5-fold (0.65 log units) between middle value and limit.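

In this assay compound 3 gives a limit and not a number: the limit of > 50000 nM in this assay, at which 1 of the 3 values shown sits. Replacing the group on the nitrogen with 3-fluorophenyl gives an at least 9.3-fold higher number from compound 2 to compound 3 (0.97 log units; beyond the scatter) and an at least 4.2-fold higher number from compound 1 to compound 3 (0.62 log units; beyond the scatter), so this position can move the read-out further than a 2.2-fold lower number from compound 1 to compound 2 (0.34 log units; beyond the scatter) had indicated. Compounds 1 and 2 both give numbers despite carrying different groups here, whereas compound 3, with fewer heavy atoms in this group than 4-chloro-3-(trifluoromethyl)phenyl, gives only the limit, so the position is not indifferent to the aryl group.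

Going by these compounds, the full size of both new steps stays unknown, since each rests on that limit. On these data alone, it also remains open how 4-chlorophenyl, 3-(trifluoromethyl)phenyl or unsubstituted phenyl would read here, so the contribution of each group on the ring cannot be separated.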